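Working notes on the amide substituent step in this assay

This account rests on a few compounds, and the source may have more. Where it says the series, first, only, none or still open, it means among the compounds named here.

Measured compounds, read in an assay on isolated protein for inhibition of tyrosine-protein phosphatase non-receptor type 13 (Homo sapiens), read by spectrophotometry; on this read-out lower numbers stand for stronger inhibition and higher numbers for weaker inhibition:
Compound 1 `Oc1cc(-c2ccccc2)ccc1C(O)(C(F)(F)F)C(F)(F)F`: compound 1 gives > 500000 nM, a limit of the assay.
Compound 2 `CCN(CC)C(=O)COc1ccc2cc(C(O)(C(F)(F)F)C(F)(F)F)c(O)cc2c1`: compound 2 gives > 20000 nM, a limit of the assay.
Compound 3 `Oc1c(-c2ccccc2)cccc1C(O)(C(F)(F)F)C(F)(F)F`: compound 3 gives 449000 nM.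

Compound 2 stands only at the limit of > 20000 nM in this assay, at which 1 of the 3 values shown sits. Compound 1 stands at the limit of > 500000 nM in this assay, at which 1 of the 3 values shown sits. For the measured compounds named here, only compound 3 gives a number in this assay, and no two measured compounds differ in a single place, so no measured step exists to lean on.

Compound 4 `COc1ccc(CNC(=O)COc2ccc3cc(C(O)(C(F)(F)F)C(F)(F)F)c(O)cc3c2)cc1OC` differs from compound 2 by (3,4-dimethoxybenzyl)amino in place of diethylamino on a carbonyl carbon, in words (3,4-dimethoxybenzyl)amino in place of diethylamino on a carbonyl carbon. With compound 2 at a limit, no step beyond the usual scatter is expected in either direction from this change alone. Compound 4 is expected near 30000 nM, within 5000 nM to 200000 nM, which corresponds to an expected step that the limit leaves unreadable from compound 2 to compound 4.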

Compound 4, half-maximal inhibitory concentration: > 20000 nM
Compound 4 ended at the assay's limit; the forecaster's own chance of this, stated with the estimate: 60%; the middle value is on the limit's open side.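

Compound 2 and compound 4 both stand at a limit in this assay, and no step between them can be read: the limit of > 20000 nM in this assay, at which 2 of the 4 values shown sit.

Going by these compounds, whether (3,4-dimethoxybenzyl)amino in place of diethylamino on a carbonyl carbon changes inhibition at all remains open.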